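The compounds below may be only part of what the source reports. "The series", "measured", "known", "first", "only" and "open" are said of these compounds alone.

Among three compounds built on one shared core, compound 3 `CC(C)/C(=C(/c1ccc(/C=C/C(=O)O)cc1)c1ccc2[nH]ncc2c1)c1ccccc1` gives the lowest number in a functional assay on MCF7 cells (Homo sapiens) for cytotoxicity, read by CellTiter-Glo, with a stated time of 5 days (a lower number here means a stronger inhibitor, a higher number a weaker inhibitor), at 4 nM. Compound 2 `CCCC/C(=C(/c1ccc(/C=C/C(=O)O)cc1)c1ccc2[nH]ncc2c1)c1ccccc1` gives 10 nM in this assay, and compound 1 `C/C(=C(/c1ccc(/C=C/C(=O)O)cc1)c1ccc2[nH]ncc2c1)c1ccccc1` gives 40 nM. The measured steps run a 4.0-fold lower number from compound 1 to compound 2 (0.60 log units; beyond the scatter), a 10-fold lower number from compound 1 to compound 3 (1.00 log units; beyond the scatter) and a 2.5-fold lower number from compound 2 to compound 3 (0.40 log units; beyond the scatter). Compound 4 `O=C(O)/C=C/c1ccc(/C(=C(\c2ccccc2)C2CCCC2)c2ccc3[nH]ncc3c2)cc1` differs from compound 3 in a single place: cyclopentyl in place of isopropyl on a double-bonded chain carbon bound to an aromatic carbon and a double-bonded chain carbon. The steps into compound 3 bear on this change, since both enlarge or reshape the group at the same carbon and both lowered the number. Because a 10-fold lower number from compound 1 to compound 3 (1.00 log units; beyond the scatter) was the largest step and compound 3 already sits lowest, only a small further lowering, or none beyond the scatter, is expected, a 1.3-fold lower number from compound 3 to compound 4 (0.12 log units; within the scatter). Compound 4 is estimated at 3 nM, ranging from 1 nM to 10 nM.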

Compound 4, half-maximal inhibitory concentration: 10 nM
For compound 4 the middle estimate is 3.3-fold (0.52 log units) below the measured one; the range from low to high includes it.
By their numbers in this assay, from the lowest: compound 3; then compounds 2 and 4 (each within the scatter of the next); then compound 1.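

In this assay the number at this carbon does not simply keep falling as the group grows: swapping isopropyl for cyclopentyl gives a 2.5-fold higher number from compound 3 to compound 4 (0.40 log units; beyond the scatter) and so reverses the earlier trend. The ring still keeps much of the gain over methyl, with a 4.0-fold lower number from compound 1 to compound 4 (0.60 log units; beyond the scatter). Against the open butyl chain it shows no change at the digits printed from compound 2 to compound 4 (within the scatter), so ring and chain cannot be told apart here.

Nothing available explains the rise seen with the ring. On these data alone, whether cyclopropyl or tert-butyl at this carbon would match isopropyl stays open.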